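Compound 4: cyano in place of chloro

This account rests on a few compounds, and the source may have more. Where it says the series, first, only, none or still open, it means among the compounds named here.

Of the compounds shown here, three have been measured in a functional assay on HCC1937 cells (Homo sapiens) for antiproliferative activity, read by CCK-8 assay, with a stated time of 72 h; a lower number here means a stronger inhibitor, a higher number a weaker inhibitor. Compound 1 `O=C(Nc1cccc(-c2oc3cc(-c4ccc(F)cc4)ccc3c(=O)c2O)c1)c1ccc(F)cc1` gives 14200 nM, compound 2 `O=C(Nc1cccc(-c2oc3cc(-c4ccc(F)cc4)ccc3c(=O)c2O)c1)c1ccc(Cl)cc1` gives 4030 nM, and compound 3 `COc1ccc(C(=O)Nc2cccc(-c3oc4cc(-c5ccc(F)cc5)ccc4c(=O)c3O)c2)c(F)c1` gives 24500 nM. Compound 2 holds the lowest number of the three: the step of a 3.5-fold lower number from compound 1 to compound 2 (0.55 log units; beyond the scatter) and the step of a 6.1-fold higher number from compound 2 to compound 3 (0.78 log units; beyond the scatter) both lie beyond the scatter, whereas a 1.7-fold higher number from compound 1 to compound 3 (0.24 log units; within the scatter) does not.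

Compound 4 `N#Cc1ccc(C(=O)Nc2cccc(-c3oc4cc(-c5ccc(F)cc5)ccc4c(=O)c3O)c2)cc1` differs from compound 2 in one place: cyano in place of chloro on an aromatic carbon. For the measured compounds named here, no measured pair shows this exact exchange. Going by the values given here, the only step at the same place is a 3.5-fold lower number from compound 1 to compound 2 (0.55 log units; beyond the scatter), halogen for halogen; the other two steps replace the whole ring on the carbonyl carbon. Taken together they show that what sits on that ring moves this assay by modest amounts, and that chloro gave the lowest number so far. With nothing directly comparable, the expectation for compound 4 is a higher number than compound 2, of roughly the size seen between compound 1 and compound 2 rather than a further drop, so the expected step is a 2.2-fold higher number from compound 2 to compound 4 (0.35 log units; beyond the scatter), with wide uncertainty. The estimate for compound 4 in this assay is 9000 nM, with a range from 3000 nM to 30000 nM.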

Compound 4, half-maximal inhibitory concentration: 2990 nM
Estimate against measurement, compound 4: 3.0-fold (0.48 log units) above; measured number outside the range, below it.
By their numbers in this assay, from the lowest: compounds 4 and 2 (each within the scatter of the next); then compounds 1 and 3 (each within the scatter of the next).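

In this assay, the step of a 1.3-fold lower number from compound 2 to compound 4 (0.13 log units; within the scatter) lies within the scatter, so at this place on the ring, para to a large group, cyano and chloro cannot be told apart. The position is therefore not confined to halogens: a nitrile, with its triple bond and hydrogen-bond acceptor, serves as well as chloro, while fluoro is the halogen that stands apart, as the step of a 4.7-fold lower number from compound 1 to compound 4 (0.68 log units; beyond the scatter) now shows alongside the earlier chloro result. The step of an 8.2-fold lower number from compound 3 to compound 4 (0.91 log units; beyond the scatter) places 4-cyanophenyl with 4-chlorophenyl, beyond the scatter from 2-fluoro-4-methoxyphenyl, so the ring substituents shown fall into a lower pair, chloro and cyano, and a higher pair, fluoro and 2-fluoro-4-methoxy.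

No measurement shown accounts for why cyano and chloro match each other or why fluoro differs from both. Going by these compounds, it also remains open how this position responds to an amine, a carboxylic acid, a trifluoromethyl group or a longer alkyl chain, and whether any of these would move the number beyond that of the chloro and cyano pair.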